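Thiophen-2-yl to phenyl: projecting compound 4

This account rests on a few compounds, and the source may have more. Where it says the series, first, only, none or still open, it means among the compounds named here.

Measured so far:
- compound 1 `COc1cc(C(=O)c2sc(-c3cccs3)cc2N)cc(OC)c1OC`: 8.9 nM
- compound 2 `CCOc1ccc(-c2cc(N)c(C(=O)c3cc(OC)c(OC)c(OC)c3)s2)cc1`: 240 nM
- compound 3 `COc1cc(C(=O)c2sc(-c3ccncc3)cc2N)cc(OC)c1OC`: 88 nM

In a functional assay on MOLT-4 cells (Homo sapiens) for antiproliferative activity (on this read-out higher numbers stand for weaker inhibition and lower numbers for stronger inhibition), compound 1 gives the lowest number of the three. Its nearest neighbour is compound 3 with a 9.9-fold higher number from compound 1 to compound 3 (1.00 log units; beyond the scatter), and the furthest is compound 2 with a 27-fold higher number from compound 1 to compound 2 (1.43 log units; beyond the scatter). Both steps lie beyond the scatter.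

Compound 4 `COc1cc(C(=O)c2sc(-c3ccccc3)cc2N)cc(OC)c1OC` has not yet been tested in this assay. It differs from compound 1 in one place: phenyl in place of thiophen-2-yl on an aromatic carbon. The change sits on an aromatic carbon of a five-membered aromatic ring with 1 sulfur, next to the ring sulfur.

Among the compounds with values here, two measured steps bear on this change, both of which replace the thiophen-2-yl group of compound 1 by a six-membered aromatic ring: a 27-fold higher number from compound 1 to compound 2 (1.43 log units; beyond the scatter) and a 9.9-fold higher number from compound 1 to compound 3 (1.00 log units; beyond the scatter). Both point the same way, toward higher numbers, and both exceed the scatter. Phenyl carries neither the ethoxy of compound 2 nor the ring nitrogen of compound 3, so the bare six-membered ring is expected to cost less than either, yet still a step beyond the scatter is expected, estimated as a 3.4-fold higher number from compound 1 to compound 4 (0.53 log units; beyond the scatter).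

Compound 4 is therefore expected at about 30 nM in this assay, with a range from 8 nM to 110 nM.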

Compound 4, half-maximal inhibitory concentration: 5.3 nM
Beside the measured number, compound 4's estimate is 5.7-fold (0.75 log units) above it, and the stated range ends above it.
By their numbers in this assay, from the lowest: compounds 4 and 1 (each within the scatter of the next); then compound 3; then compound 2.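

In this assay, a six-membered aromatic ring as such carries no penalty on this aromatic carbon next to the ring sulfur: phenyl in place of thiophen-2-yl gives (a 1.7-fold lower number from compound 1 to compound 4 (0.23 log units; within the scatter)), so the two groups cannot be told apart on this read-out. The higher numbers of the two earlier six-membered analogues therefore go with what those rings carry, not with the change of ring itself: hydrogen in place of ethoxy gives (a 45-fold lower number from compound 2 to compound 4 (1.66 log units; beyond the scatter)), and phenyl in place of pyridin-4-yl gives (a 17-fold lower number from compound 3 to compound 4 (1.22 log units; beyond the scatter)). Ethoxy and the ring nitrogen of pyridin-4-yl each mark a sensitive change on this aryl group, but nothing available here accounts for either step.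

Open, on these data alone, is whether the loss seen with ethoxy scales with the size of the substituent, which a methoxy group, a fluorine or a longer alkoxy chain on the phenyl of compound 4 would help to separate. Also open, as far as these compounds go, is whether the loss seen with pyridin-4-yl holds for other ring forms, such as pyridin-3-yl or pyridin-2-yl, and whether furan-2-yl would match thiophen-2-yl and phenyl at this position.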